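The source may report more compounds than this note shows. Statements on the series, on what has been measured and on what is new or still open speak of the compounds shown alone.

Compound 1 `N#Cc1c(Cl)nc(SCc2nc3ccccc3[nH]2)nc1-c1ccccc1`: 8.62 nM
Compound 2 `N#Cc1c(NN)nc(SCc2nc3ccccc3[nH]2)nc1-c1ccccc1`: 2.68 nM
Compound 3 `N#Cc1c(Nc2ccccc2)nc(SCc2nc3ccccc3[nH]2)nc1-c1ccccc1`: 6.41 nM
Compound 4 `CNc1nc(SCc2nc3ccccc3[nH]2)nc(-c2ccccc2)c1C#N`: not yet measured

In a functional assay on GOTO cells (Homo sapiens) for cytotoxicity, read by MTT assay, with a stated time of 3 days (on this read-out lower numbers stand for stronger inhibition and higher numbers for weaker inhibition), compound 3 gives 6.41 nM. The data show a 1.3-fold lower number from compound 1 to compound 3 (0.13 log units; within the scatter), and also a 2.4-fold higher number from compound 2 to compound 3 (0.38 log units; beyond the scatter). Compound 4 carries methyl in place of phenyl on a nitrogen on an aromatic ring. The nearest measured parallel is that second step, which involves the same nitrogen, though with amino rather than methyl as the partner of phenyl. Another step, a 3.2-fold lower number from compound 1 to compound 2 (0.51 log units; beyond the scatter), is also modest. A modest drop at most is therefore expected, and it may stay within the scatter. The expected change is a 1.4-fold lower number from compound 3 to compound 4 (0.15 log units; within the scatter). For compound 4 the estimate is 4.5 nM, with an expected range from 2 nM to 10 nM.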

Compound 4, half-maximal inhibitory concentration: 3.28 nM
The estimate for compound 4 lay 1.4-fold (0.14 log units) above the measured number, and the stated range covers the measured number.
By their numbers in this assay, from the lowest: compounds 2, 4, 3 and 1 (each within the scatter of the next, the first and the last beyond it).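

In this assay, methyl in place of phenyl on the nitrogen gives a 2.0-fold lower number from compound 3 to compound 4 (0.29 log units; within the scatter) and methyl in place of amino gives a 1.2-fold higher number from compound 2 to compound 4 (0.09 log units; within the scatter), so the small methylamino group reads alike with the anilino and aminoamino groups here, and the phenyl ring is not required for a low number. Methylamino in place of chloro gives a 2.6-fold lower number from compound 1 to compound 4 (0.42 log units; beyond the scatter), joining aminoamino in clearing the scatter from chloro, whereas anilino does not. Nothing available explains these steps. Going by these compounds, whether a longer chain such as propyl, or a morpholine ring, would keep the number this low at this position stays open.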